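Chloro to cyano at the limit of the assay

The source may report more compounds than this note shows. Statements on the series, on what has been measured and on what is new or still open speak of the compounds shown alone.

In a functional assay on HCT-116 cells (Homo sapiens) for antiproliferative activity, with a stated time of 48 h (a lower number here means a stronger inhibitor, a higher number a weaker inhibitor), compound 1 `COc1ccc(Nc2ccc(-c3ccccc3)nn2)cc1` gives > 25000 nM as its reading, which is a limit and not a number. Compound 2 `CCN(CC)c1ccc(-c2cccc(Cl)c2)nn1` gives > 25000 nM as its reading, and this too is only a limit. The record so far therefore comes down to the limit of > 25000 nM in this assay, at which 2 of the 2 values shown sit, and holds no measured number for either compound.

Compound 3 `CCN(CC)c1ccc(-c2cccc(C#N)c2)nn1` differs from compound 2 in one place, meta to a large group, where the change is cyano in place of chloro on an aromatic carbon and the rest of the structure stays the same. For the measured compounds named here, no measured pair of compounds shows what such a swap does in this assay so the expectation has only compound 2 to start from. No change beyond the usual scatter is expected, in either direction. The expected step is a step that the limit leaves unreadable from compound 2 to compound 3 and it should not be read as a real gain or loss. Compound 3 is estimated to read about 30000 nM with an expected range from 12000 nM to 60000 nM and the reading may well come back as a limit again.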

Compound 3, half-maximal inhibitory concentration: > 25000 nM
Compound 3: only a limit was reported; the forecaster's own chance of this, stated with the estimate: 75%; the middle value is on the limit's open side.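

In this assay compound 3 gives > 25000 nM, which is again a limit and not a number. For the compounds shown here, compound 2 also has only a limit, so no step from compound 2 to compound 3 can be read for cyano in place of chloro. The compounds shown leave open what any of these structures would measure as a number, because all of them share one reading: the limit of > 25000 nM in this assay, at which 3 of the 3 values shown sit.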